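Dropping a Methoxy from a Pyridyl Chalcone

The source may report more compounds than this note shows. Statements on the series, on what has been measured and on what is new or still open speak of the compounds shown alone.

Among the measured compounds shown here, compound 2 `COc1ccc(C(=O)/C=C/c2cn(-c3ccccc3)nc2-c2ccncc2)c(OC)c1OC` gives 3300 nM in a functional assay on MCF7 cells (Homo sapiens) for inhibition, read by sulforhodamine B assay, with a stated time of 72 h (a higher number here means a weaker inhibitor, a lower number a stronger inhibitor), which places it at the top of the two numbers measured so far, although compound 1 `COc1ccc(C(=O)/C=C/c2cn(-c3ccccc3)nc2-c2ccsc2)cc1OC` gives 2800 nM in this assay and the gap between the two lies within the usual scatter. Compound 3 `COc1ccc(C(=O)/C=C/c2cn(-c3ccccc3)nc2-c2ccncc2)cc1OC` differs from compound 2 by hydrogen in place of methoxy on an aromatic carbon. For the measured compounds named here, no step between measured compounds shows the effect of such a change, so compound 3 is expected to stay close to compound 2, with the step of a 1.1-fold lower number from compound 2 to compound 3 (0.04 log units; within the scatter) expected to be no larger than the scatter. Compound 3 is estimated at 3000 nM, with a range from 1200 nM to 8000 nM.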

Compound 3, half-maximal inhibitory concentration: 4300 nM
Beside the measured number, compound 3's estimate is 1.4-fold (0.16 log units) below it; the range from low to high includes it.
By their numbers in this assay, from the lowest: compounds 1, 2 and 3 (each within the scatter of the next).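

Hydrogen in place of methoxy, at the aromatic carbon ortho to a large group, gives a 1.3-fold higher number from compound 2 to compound 3 (0.11 log units; within the scatter) in this assay and so leaves the number within the scatter. Pyridin-4-yl in place of thiophen-3-yl gives a 1.5-fold higher number from compound 1 to compound 3 (0.19 log units; within the scatter) and likewise stays within the scatter, so neither change separates these compounds. No measured evidence bears on these two steps. Going by these compounds, whether a hydroxy group, an amine or a longer chain such as ethoxy at this carbon would move the number beyond the scatter remains open. Also open, on these data alone, is what removing either remaining methoxy group would do.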